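This account rests on a few compounds, and the source may have more. Where it says the series, first, only, none or still open, it means among the compounds named here.

Measured so far:
compound 1, `c1ccc(-c2cccc3c2CCC3c2ncc[nH]2)nc1`, 53%
compound 2, `CCS(=O)(=O)Nc1cccc(Cc2c[nH]cn2)c1`, 96%
compound 3, `COc1c(Cl)ccc2c1CCC2c1ncc[nH]1`, 24%

All three were tested in a functional assay on CHO cells for agonist activity at Alpha-1A adrenergic receptor (Homo sapiens), read by FLIPR and calcium flux (a lower number here means a smaller maximal response, a higher number a larger maximal response), which records how large a response each compound can produce. Compound 1 stands second of the three. Sharing the core of compound 1, compound 3 gives 24%, lower than compound 1 by more than the usual scatter. Compound 2, built on a different core, gives 96%, higher than compound 1 by well more than the scatter. No two of the three differ in only one place, so no single structural change can yet be read from the measured set.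

Compound 4, `CCS(=O)(=O)Nc1cccc2c1CCC2c1ncc[nH]1`, has not been measured. Against compound 1 it differs in one place: (ethylsulfonyl)amino in place of pyridin-2-yl on an aromatic carbon. The group that enters is the same (ethylsulfonyl)amino group that compound 2 carries on its own core. An upward step is expected because compound 2 with the same group gives 96%, though its core is not the core of compound 1. The step of a number 22 percentage points higher from compound 1 to compound 4 (beyond the scatter) is expected to lie beyond the scatter, upward. For compound 4 the estimated value is 75%, with a range from 45% to 100%.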

Compound 4, largest response reached (Emax), in percent of the reference or control that the assay uses: 86%
Estimate against measurement, compound 4: 11 percentage points below; measured number inside the range.
By their numbers in this assay, from the lowest: compound 3; then compound 1; then compounds 4 and 2 (each within the scatter of the next).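

Among the compounds shown here, replacing pyridin-2-yl with (ethylsulfonyl)amino on this aromatic carbon, ortho to a fused ring, gives the first reading of a single change in this set: in this assay, it produces a rise of a number 33 percentage points higher from compound 1 to compound 4 (beyond the scatter). So the maximal response on this core depends strongly on the group at this position, a link that the earlier compounds, none differing in only one place, could not show. The two groups have the same heavy-atom count but differ in other ways, since (ethylsulfonyl)amino has no ring and carries a hydrogen-bond donor, and nothing shown indicates which difference, if any, accounts for the rise.

On these data alone, with only these two groups compared here, it remains open whether the whole (ethylsulfonyl)amino group is needed, or whether a simple amine, an acetylamino group, a methylsulfonylamino group or a longer chain on the sulfonyl would give a similar response. As far as these compounds go, it is also open whether the same swap would have a similar effect on a core carrying other substituents, such as the methoxy and chloro groups of compound 3.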